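From a butyl to a fluoro on the shared core

The compounds below may be only part of what the source reports. "The series", "measured", "known", "first", "only" and "open" are said of these compounds alone.

Compound 1 `CCCCc1ccc(NC(=O)N[C@H](C)c2ccccc2)cc1` gives 32%
Compound 2 `CCCCc1ccc(NC(=O)N[C@@H](C)c2ccccc2)cc1` gives 72%
Compound 3 `CCOC(=O)c1cccc(NC(=O)N[C@H](C)c2ccccc2)c1` gives 94%

In an ADME assay on the whole organism with Oryza sativa as the target, tested at 1 uM (on this read-out higher numbers stand for a weaker effect at the one concentration tested and lower numbers for a stronger effect), compound 2 stands second highest of the three numbers, with compound 3 above it and compound 1 below it. For the measured compounds named here, the only measured step, a number 40 percentage points higher from compound 1 to compound 2 (beyond the scatter), goes with the fact that compounds 1 and 2 differ only in the configuration as drawn and so concerns the stereocentre rather than any group on the ring. The unmeasured compound 4 `C[C@H](NC(=O)Nc1ccc(F)cc1)c1ccccc1` differs from compound 2 by fluoro in place of butyl on an aromatic carbon. Going by the values given here, no measured step alters a group on that ring, so nothing here sets a direction, and the value of compound 2 is the nearest guide. The step of a number 3 percentage points higher from compound 2 to compound 4 (within the scatter) is therefore expected to stay within the scatter. The estimate for compound 4 is 75%, between 45% and 100%.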

Compound 4, a percentage reported as activity, at one concentration (the size of the read-out at that concentration, not a potency): 97%
Compound 4: the middle estimate sits 22 percentage points below what was measured; measured number inside the range.
By their numbers in this assay, from the lowest: compound 1; then compound 2; then compounds 3 and 4 (each within the scatter of the next).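

For the compounds shown here, the step of a number 25 percentage points higher from compound 2 to compound 4 (beyond the scatter) is the first measured change of a group on the ring, and it shows that in this assay the number responds to the group on this aromatic carbon, not only to the stereocentre. Fluoro in place of butyl here goes with a weaker effect at the one concentration tested. No measured property bears on the cause of this step. The compounds shown leave open whether an ethyl group, a longer chain or an amine on this carbon would keep the stronger effect seen with butyl. They also leave open whether reversing the stereocentre would move the number with fluoro as it does with butyl.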